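The source may hold more compounds than are shown below. What is called first, only, known or untested is meant among the compounds shown, and "the series" means these compounds.

Compound 1, `Cc1cc(N2CCCCC2)nc(SCc2nc3ccccc3[nH]2)n1`, gives only the assay's limit > 100000 nM in a functional assay on ECa-109 cells (Homo sapiens) for cytotoxicity, read by MTT assay, with a stated time of 72 h; on this read-out higher numbers stand for weaker inhibition and lower numbers for stronger inhibition.
Compound 2, `Cc1cc(NCCO)nc(SCc2nc3ccccc3[nH]2)n1`, likewise reaches only the limit > 100000 nM in this assay.
Compound 3, `Cc1cc(Nc2ccc(Br)cc2)nc(SCc2nc3ccccc3[nH]2)n1`, gives 42900 nM in this assay.

Compound 3 is thus the only one of the three with an actual number; the other two values are limits of the assay, at which no number could be read. The compound not yet measured, compound 4, `COc1ccccc1Nc1cc(C)nc(SCc2nc3ccccc3[nH]2)n1`, differs from compound 3 in one place: 2-methoxyphenyl in place of 4-bromophenyl on a nitrogen on an aromatic ring. Among the compounds with values here, two measured steps bear on this nitrogen. Replacing the 2-hydroxyethyl by the 4-bromophenyl gave an at least 2.3-fold lower number from compound 2 to compound 3 (0.36 log units; beyond the scatter), and replacing the piperidin-1-yl by the (4-bromophenyl)amino gave an at least 2.3-fold lower number from compound 1 to compound 3 (0.36 log units; beyond the scatter); both start from the limit of > 100000 nM in this assay, at which 2 of the 3 values shown sit, so their true size is not readable. Within the data shown here, they show only that an aromatic ring on this nitrogen produced a measurable number where a chain or a saturated ring did not. Among the measured compounds shown here, compound 4 keeps an aromatic ring there but exchanges the bromine for a methoxy group, and no measured step tells how such an exchange reads out. The step from compound 3 to compound 4 is therefore expected to stay roughly within the scatter, a 1.3-fold higher number from compound 3 to compound 4 (0.11 log units; within the scatter), with some chance of a weaker number. For compound 4 the estimated value in this assay is 55000 nM, expected to fall between 18000 nM and 150000 nM.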

Compound 4, half-maximal inhibitory concentration: 34400 nM
For compound 4 the middle estimate is 1.6-fold (0.20 log units) above the measured one, within the range that was stated.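

In this assay, exchanging the group on this nitrogen gives a 1.2-fold lower number from compound 3 to compound 4 (0.10 log units; within the scatter), so 4-bromophenyl and 2-methoxyphenyl read alike here, although one carries a bromine and the other a methoxy group that adds a hydrogen-bond acceptor. A measurable number with an aromatic ring on this nitrogen therefore no longer rests on a single compound or on the bromine, and all four compounds fit this pattern. The steps from the two compounds without such a ring point the same way, an at least 2.9-fold lower number from compound 2 to compound 4 (0.46 log units; beyond the scatter) and an at least 2.9-fold lower number from compound 1 to compound 4 (0.46 log units; beyond the scatter), but each starts from a limit of the assay rather than a number, so its true size cannot be read: the limit of > 100000 nM in this assay, at which 2 of the 4 values shown sit.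

The two rings differ both in the group they carry and in where it sits, so the compounds shown cannot separate these two changes; 2-bromophenyl or 4-methoxyphenyl on the same nitrogen would do so. Going by these compounds, it also remains open how a plain phenyl ring, or a ring carrying an amine or a carboxylic acid, would read in this assay.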